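The compounds below may be only part of what the source reports. "The series", "measured", "known", "first", "only" and "open" are said of these compounds alone.

Two compounds share one core and differ only in the group fixed to the carbonyl carbon of the amide. Compound 1 `CC(C)(C)C(=O)N1CCN(c2nc(=O)c3cc(C(F)(F)F)cc([N+](=O)[O-])c3s2)CC1` carries a tert-butyl there, and in a physicochemical assay for solubility, read by HPLC (on this read-out higher numbers stand for higher solubility and lower numbers for lower solubility), compound 1 gives 5.87 ug/mL. Compound 2 `CC(C)CC(=O)N1CCN(c2nc(=O)c3cc(C(F)(F)F)cc([N+](=O)[O-])c3s2)CC1` carries an isobutyl instead, and in this assay compound 2 gives 66.3 ug/mL, the higher of the two numbers; the change was an 11-fold higher number from compound 1 to compound 2 (1.05 log units; beyond the scatter). Compound 3 `CCC(=O)N1CCN(c2nc(=O)c3cc(C(F)(F)F)cc([N+](=O)[O-])c3s2)CC1` has not been measured. It differs from compound 2 in that (methyl in place of isopropyl on a saturated chain carbon bound to a carbonyl carbon); put another way, the isobutyl becomes an ethyl. For the measured compounds named here, no measured step covers this exact change. Going by the values given here, the single measured step shows that this read-out responds strongly to what sits on the carbonyl carbon, and the change to compound 3 is another reshaping of that group. The expected step is a 1.8-fold higher number from compound 2 to compound 3 (0.26 log units; within the scatter), moderate and upward, though with wide uncertainty. For compound 3 the estimate in this assay is 120 ug/mL, within a range of 40 ug/mL to 350 ug/mL.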

Compound 3, solubility: 3.29 ug/mL
Estimate against measurement, compound 3: 36-fold (1.56 log units) above, and the stated range ends above it.
By their numbers in this assay, from the lowest: compounds 3 and 1 (each within the scatter of the next); then compound 2.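

Shortening the isobutyl to an ethyl gives a 20-fold lower number from compound 2 to compound 3 (1.30 log units; beyond the scatter) in this assay, so the large rise seen earlier does not continue as this group gets smaller. Going from tert-butyl to ethyl gives a 1.8-fold lower number from compound 1 to compound 3 (0.25 log units; within the scatter) and stays within the scatter, so these two groups cannot be told apart here, and among these three compounds only the isobutyl of compound 2 stands clear of the others. Nothing available explains why the isobutyl stands apart.

Three compounds cannot show whether the high number belongs to the isobutyl alone or to any chain of that length. A straight butyl chain, a longer chain or a cyclopropylmethyl group on the same carbonyl carbon would test this, and a chain ending in an amine remains an open question too.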